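A few compounds are considered here, and "the series" means these few. Any claim that something is new, unique, unknown or untested is made for them only; others in the source may bear on it.

Measured so far:
compound 1 `O=c1cc(-c2ccc([N+](=O)[O-])cc2)oc2cc(O)ccc12` — in a functional assay on SK-MEL cells (Homo sapiens) for cytotoxicity, read by MTT assay, with a stated time of 6 days (a lower number here means that less compound is needed, a higher number that more compound is needed for the effect), compound 1 gives only a limit of the assay, > 25 ug/mL.
compound 2 `O=c1cc(-c2ccc([N+](=O)[O-])cc2)oc2c(O)c(O)ccc12` — in this assay compound 2 gives 3.29 ug/mL.
compound 3 `COc1cc(-c2cc(=O)c3ccc(O)cc3o2)cc(OC)c1O[Si](C)(C)C(C)(C)C` — in this assay compound 3 gives only a limit of the assay, > 25 ug/mL.

From compound 1 to compound 2 the change is hydroxy in place of hydrogen on an aromatic carbon. The step it made is an at least 7.5-fold lower number from compound 1 to compound 2 (0.88 log units; beyond the scatter); as the starting value is a limit, the true size is open upward, and the limit of > 25 ug/mL in this assay, at which 2 of the 3 values shown sit, is where the starting point sits.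

Compound 4 `COc1cc(-c2cc(=O)c3ccc(O)c(O)c3o2)cc(OC)c1O[Si](C)(C)C(C)(C)C` is not yet measured. For the measured compounds named here, it carries the same change as the one from compound 1 to compound 2, namely (hydroxy in place of hydrogen on an aromatic carbon); the two place descriptions agree word for word. How the core of compound 3 differs from the core of compound 1 is not broken down here.

Going by the values given here, for compound 4 in this assay the expected step is an at least 3.1-fold lower number from compound 3 to compound 4 (0.49 log units; beyond the scatter), resting on the one measured step of this change, an at least 7.5-fold lower number from compound 1 to compound 2 (0.88 log units; beyond the scatter), and on compound 3 standing at a limit, > 25 ug/mL. The estimate for compound 4 is 8 ug/mL, with a range from 2.5 ug/mL to 25 ug/mL; a reported limit remains a real possibility.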

Compound 4, concentration for half-maximal effect: 0.11 ug/mL
Compound 4: the middle estimate sits 73-fold (1.86 log units) above what was measured, and the stated range ends above it.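

Hydroxy in place of hydrogen on an aromatic carbon again gives a lower number in this assay on a second core, an at least 220-fold lower number from compound 3 to compound 4 (2.35 log units; beyond the scatter). The change therefore carries over in direction across the two cores shown, but two pairs are no basis for a rule across the series, and neither step has a closed size since each starts from a limit. Whether the core alters the size of the step stays undecided, as the two steps set side by side show: the same change on two cores in this assay, an at least 7.5-fold lower number (0.88 log units; beyond the scatter) from compound 1 to compound 2 and an at least 220-fold lower number (2.35 log units; beyond the scatter) from compound 3 to compound 4; the limit leaves it open whether they differ

Open is whether the hydroxy group itself is needed, since a methoxy group or an amine in its place is not among the compounds shown. Also open, as far as these compounds go, is how the change behaves on cores carrying a carboxylic acid or a longer chain in place of the nitro group or the silyl ether, and on a core whose starting value is a measured number rather than a limit.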